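Thiourea amide series: nitrophenyl variant on HeLa growth

The source may report more compounds than this note shows. Statements on the series, on what has been measured and on what is new or still open speak of the compounds shown alone.

Working notes on the series. Going by the values given here, compound 1 `NC(=O)c1c(NC(=O)c2ccccc2Cl)sc2c1CCN(C(=S)Nc1cc(C(F)(F)F)cc(C(F)(F)F)c1)C2` is the only member of this set to give a number in a functional assay on HeLa cells (Homo sapiens) for antiproliferative activity, with a stated time of 24 h; on this read-out higher numbers stand for weaker inhibition and lower numbers for stronger inhibition: compound 1 gives 48900 nM. Compound 2 `NC(=O)c1c(NC(=O)c2cccc([N+](=O)[O-])c2)sc2c1CCN(C(=O)Nc1ccccc1Cl)C2` carries a urea rather than the thiourea of compound 1, together with a 3-nitrophenyl amide. In this assay compound 2 returns only a limit, > 50000 nM. Of the two readings shown, (the limit of > 50000 nM in this assay, at which 1 of the 2 values shown sits). Among the compounds with values here, no step between measured compounds can be computed, since compound 1 and compound 2 differ in two places at once; their two values show both sitting at the weak end of the range.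

Compound 3 `NC(=O)c1c(NC(=O)c2cccc([N+](=O)[O-])c2)sc2c1CCN(C(=S)Nc1cc(C(F)(F)F)cc(C(F)(F)F)c1)C2` is not yet measured. It differs from compound 1 by 3-nitrophenyl in place of 2-chlorophenyl on a carbonyl carbon, while the thiourea of compound 1 is kept. Nothing measured isolates this exchange. The expectation is a step of a 1.1-fold higher number from compound 1 to compound 3 (0.05 log units; within the scatter), no larger than the scatter and with no clear direction, given that compound 1 already sits at 48900 nM near where counting stops. Compound 3 is therefore estimated at 55000 nM, within 25000 nM to 120000 nM, with a fair chance that only a limit is reported.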

Compound 3, half-maximal inhibitory concentration: 27200 nM
The estimate for compound 3 lay 2.0-fold (0.31 log units) above the measured number; the measured number falls inside the stated range.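

With the thiourea of compound 1 kept, 3-nitrophenyl in place of 2-chlorophenyl on a carbonyl carbon gives a 1.8-fold lower number from compound 1 to compound 3 (0.25 log units; within the scatter) in this assay. Going by these compounds alone, this is the first reading of a single change, and it shows that the two aryl groups are not told apart at this place by this read-out, with both compounds giving a number rather than a limit. The data shown offer no basis for assigning a cause to this step, which lies within the scatter in any case.

Within the data shown here, for compound 2 the reading is a limit, > 50000 nM, so no step involving it can be read. As far as these compounds go, it remains open whether any other group on this carbonyl carbon, such as a carboxylic acid or a longer alkyl chain in place of 3-nitrophenyl, would move the number beyond the scatter, or whether this place has little bearing on the read-out in the thiourea compounds.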